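A few compounds are considered here, and "the series" means these few. Any claim that something is new, unique, unknown or untested is made for them only; others in the source may bear on it.

Of the compounds shown here, three sharing one core have been measured in a functional assay on CHO cells for antagonist activity at prostaglandin E2 receptor EP1 subtype (Homo sapiens), read by FLIPR and calcium flux; on this read-out lower numbers stand for stronger inhibition and higher numbers for weaker inhibition. Compound 1 `CCOc1ccc(Cc2nnc(CN(c3cccc(Cl)c3C)S(=O)(=O)c3ccc(C)cc3)o2)cc1` gives 50.1 nM, compound 2 `Cc1ccc(S(=O)(=O)N(Cc2nnc(Cc3ccc(N(C)C)cc3)o2)c2cccc(Cl)c2C)cc1` gives 20 nM, and compound 3 `Cc1ccc(S(=O)(=O)N(Cc2nnc(Cc3ccccc3F)o2)c2cccc(Cl)c2C)cc1` gives 631 nM. Compound 3 thus stands highest of the three, with a gap to its nearest neighbour that lies beyond the scatter. The two steps leading into it were both large: a 13-fold higher number from compound 1 to compound 3 (1.10 log units; beyond the scatter) and a 32-fold higher number from compound 2 to compound 3 (1.50 log units; beyond the scatter), each a change of the group on the saturated chain carbon bound to an aromatic carbon. Compound 4 `Cc1ccc(S(=O)(=O)N(Cc2nnc(Cc3cccc(Cl)c3)o2)c2cccc(Cl)c2C)cc1` alters that same group: 3-chlorophenyl in place of 2-fluorophenyl on a saturated chain carbon bound to an aromatic carbon. Both measured steps bear on this change only loosely, since they swap a substituted phenyl bearing a group on a different ring carbon for the 2-fluorophenyl; neither shows what a 3-chlorophenyl does. Since the other two variants at this position, compound 1 and compound 2, sit well below compound 3, a move downward is expected, but smaller than either measured step. The expected step is a 3.2-fold lower number from compound 3 to compound 4 (0.50 log units; beyond the scatter), and compound 4 is estimated at 200 nM, within 60 nM to 700 nM.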

Compound 4, inhibition constant: 2000 nM
Beside the measured number, compound 4's estimate is 10-fold (1.00 log units) below it; the measured number lies above the stated range.
By their numbers in this assay, from the lowest: compound 2; then compound 1; then compound 3; then compound 4.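

In this assay the change on the saturated chain carbon bound to an aromatic carbon went upward, a 3.2-fold higher number from compound 3 to compound 4 (0.50 log units; beyond the scatter), so replacing 2-fluorophenyl here does not by itself lower the number. The gaps to the other two groups are wider still, a 40-fold higher number from compound 1 to compound 4 (1.60 log units; beyond the scatter) and a 100-fold higher number from compound 2 to compound 4 (2.00 log units; beyond the scatter), so both phenyl groups carrying a halogen stand well above the two carrying ethoxy or dimethylamino. Nothing available gives a reason for this order.

The compounds shown change the halogen and its ring carbon together, so 3-fluorophenyl or 2-chlorophenyl would be needed to tell these two changes apart. They also leave open whether ethoxy and dimethylamino keep their low numbers on another ring carbon, as in 3-ethoxyphenyl or 3-(dimethylamino)phenyl, and where unsubstituted phenyl would fall.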